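The source may report more compounds than this note shows. Statements on the series, on what has been measured and on what is new or still open speak of the compounds shown alone.

Measured compounds in a functional assay on HeLa cells (Homo sapiens) for antiproliferative activity, read by sulforhodamine B assay, with a stated time of 48 h; on this read-out higher numbers stand for weaker inhibition of growth and lower numbers for stronger inhibition of growth:

- compound 1 `COc1ccc(Cn2cc(CNC(=O)c3cn(-c4ccccc4)nc3-c3ccc(F)cc3)nn2)cc1`: 870 nM
- compound 2 `COc1ccc(Cn2cc(CNC(=O)c3cn(-c4ccccc4)nc3-c3ccc(Cl)cc3)nn2)cc1`: 1400 nM
- compound 3 `COc1ccc(-c2nn(-c3ccccc3)cc2C(=O)NCc2cn(Cc3ccc(F)cc3)nn2)cc1`: 500 nM

Compound 3 gives the lowest of the three numbers in this assay, with compound 1 nearest and within the scatter of it, and compound 2 furthest, beyond the scatter. Compound 4 `COc1ccc(Cn2cc(CNC(=O)c3cn(-c4ccccc4)nc3-c3ccc(OC)cc3)nn2)cc1` has not yet been measured. It differs from compound 3 by methoxy in place of fluoro on an aromatic carbon; the same difference, cut one bond further out, reads 4-fluorophenyl to 4-methoxyphenyl, or 4-fluorobenzyl to 4-methoxybenzyl.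

Among the compounds with values here, no measured step swaps fluoro for methoxy. Within the data shown here, the only measured single-point step, a 1.6-fold higher number from compound 1 to compound 2 (0.21 log units; within the scatter), changes a halogen on an aromatic carbon and stays within the scatter. It bears on the step to compound 4 only loosely, since methoxy is not a halogen. All three measured numbers sit within a narrow band, so no large shift is expected. For compound 4 the estimate is 700 nM, range 250 nM to 2000 nM. That estimate means a step of a 1.4-fold higher number from compound 3 to compound 4 (0.15 log units; within the scatter), expected to stay within the scatter.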

Compound 4, concentration for 50% growth inhibition: 450 nM
Estimate against measurement, compound 4: 1.6-fold (0.19 log units) above, within the range that was stated.
By their numbers in this assay, from the lowest: compounds 4, 3, 1 and 2 (each within the scatter of the next, the first and the last beyond it).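

Methoxy in place of chloro on the 4-phenyl group gives a 3.1-fold lower number from compound 2 to compound 4 (0.49 log units; beyond the scatter) in this assay, the first single-place step in the series to pass the scatter, whereas methoxy in place of fluoro there gives a 1.9-fold lower number from compound 1 to compound 4 (0.29 log units; within the scatter) and stays within it. At the benzyl end, 4-fluorobenzyl to 4-methoxybenzyl gives a 1.1-fold lower number from compound 3 to compound 4 (0.05 log units; within the scatter), so these two groups cannot be told apart in this assay and a group that is not a halogen is tolerated at both places. No supporting measurement is available to explain these steps.

Open, on these data alone, is whether an amine, a carboxylic acid or a longer alkoxy chain in place of methoxy would hold these numbers. Also open, as far as these compounds go, is whether the unsubstituted phenyl or benzyl would stay within the scatter of compound 4.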